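Methoxy for fluoro on the aryloxy ring

A few compounds are considered here, and "the series" means these few. Any claim that something is new, unique, unknown or untested is made for them only; others in the source may bear on it.

Compounds measured so far:
compound 1 `COc1ccc(Oc2ccccc2NC(C)=C2C(=O)CC(c3ccccc3)CC2=O)cc1` 83 nM
compound 2 `CC(Nc1ccccc1Oc1cccc(F)c1)=C1C(=O)CC(c2ccccc2)CC1=O` 360 nM

Two compounds share a core and differ only in the ring hung on the aryl ether oxygen. In a functional assay on HMEC-1 cells (Homo sapiens) for antiproliferative activity, read by cell counting, with a stated time of 4 days (on this read-out lower numbers stand for stronger inhibition and higher numbers for weaker inhibition), compound 1 gives 83 nM, while compound 2 gives 360 nM, the highest of the two numbers. Among the measured compounds shown here, the one measured step, a 4.3-fold higher number from compound 1 to compound 2 (0.64 log units; beyond the scatter), covers 3-fluorophenyl in place of 4-methoxyphenyl and thus changes both the group and its position at once.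

Compound 3 `COc1cccc(Oc2ccccc2NC(C)=C2C(=O)CC(c3ccccc3)CC2=O)c1` has not yet been measured. It differs from compound 2 by methoxy in place of fluoro on an aromatic carbon. The change brings back the methoxy group seen in compound 1, but on a different position of the ring, so the measured step bears on it only in part. Since compound 1, the methoxy-bearing analogue, gives 83 nM, a return toward a lower number in this assay is expected, though weaker than the full step a 4.3-fold higher number from compound 1 to compound 2 (0.64 log units; beyond the scatter). The expected step is a 2.3-fold lower number from compound 2 to compound 3 (0.35 log units; beyond the scatter). Compound 3 is therefore estimated at 160 nM, with a range from 60 nM to 420 nM.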

Compound 3, half-maximal inhibitory concentration: 59 nM
Beside the measured number, compound 3's estimate is 2.7-fold (0.43 log units) above it, and the stated range ends above it.
By their numbers in this assay, from the lowest: compounds 3 and 1 (each within the scatter of the next); then compound 2.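

With the position held, methoxy in place of fluoro gives a 6.1-fold lower number from compound 2 to compound 3 (0.79 log units; beyond the scatter) in this assay, so a change of group alone, with no shift of position, is enough to move the number beyond the scatter. Moving the methoxy group, 3-methoxyphenyl in place of 4-methoxyphenyl, gives a 1.4-fold lower number from compound 1 to compound 3 (0.15 log units; within the scatter), so among these three compounds its position makes no readable difference, and the gap between compound 1 and compound 2, where group and position changed together, follows the group rather than its place. Nothing given here explains why methoxy and fluoro part so clearly on this ring.

What the compounds shown leave open is whether this preference is specific to methoxy, since a hydroxyl, an ethoxy group or an amine on the same aromatic carbon would test how far the group can be altered while the number stays as low as in compound 3. Among the compounds shown here, they also leave open whether fluoro, like methoxy, would read the same at the other position, as only one fluoro compound appears here.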